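Formyl to acetyl on compound 3

The source may report more compounds than this note shows. Statements on the series, on what has been measured and on what is new or still open speak of the compounds shown alone.

In a functional assay on HeLa cells (Homo sapiens) for inhibition (a higher number here means a weaker inhibitor, a lower number a stronger inhibitor), compound 1 (`Nc1nc(O)c2ncn(/C=C/C=O)c2n1`) gives 24 uM and compound 2 (`O=C/C=C/n1c(=O)c(I)cn([C@H]2C[C@H](O)[C@@H](CO)O2)c1=O`) gives 20 uM while compound 3 (`O=C/C=C/n1c(=O)ccn([C@H]2C[C@H](O)[C@@H](CO)O2)c1=O`) gives 1 uM as the lowest of the three numbers. Compound 4 (`CC(=O)/C=C/n1c(=O)ccn([C@H]2C[C@H](O)[C@@H](CO)O2)c1=O`) carries methyl in place of hydrogen on a carbonyl carbon, formyl to acetyl (methyl in place of hydrogen on a carbonyl carbon). Going by the values given here, the only measured step (a 20-fold lower number from compound 2 to compound 3 (1.30 log units; beyond the scatter)) was large but put hydrogen in place of iodo on an aromatic carbon, so it bears only loosely on this change. With compound 3 at 1 uM as the low end of the numbers, a moderate rise rather than a further drop is expected in this assay. An estimated 3.0-fold higher number from compound 3 to compound 4 (0.48 log units; beyond the scatter) is what this expectation amounts to. Compound 4 is expected at 3 uM with a range from 0.7 uM to 15 uM as estimated here.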

Compound 4, concentration for 50% inhibition: 6 uM
Compound 4: the middle estimate sits 2.0-fold (0.30 log units) below what was measured, and the stated range covers the measured number.
By their numbers in this assay, from the lowest: compound 3; then compound 4; then compounds 2 and 1 (each within the scatter of the next).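

In this assay, going by these compounds alone, replacing formyl with acetyl gave a 6.0-fold higher number from compound 3 to compound 4 (0.78 log units; beyond the scatter) and this modest step is the first reading at the carbonyl carbon, since the earlier step concerned an aromatic carbon. It shows that this carbonyl carbon tolerates methyl in place of hydrogen, though the number rises beyond the scatter. Nothing shown here gives a cause for this step. As far as these compounds go, whether a longer chain such as propanoyl, or a carboxylic acid or an amide at this place, would raise the number further stays open. So does whether the same change would have a similar effect on compound 2, which carries iodo.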